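Compound 1 and its 4H-1,2,4-triazol-3-yl counterpart, compound 4

This account rests on a few compounds, and the source may have more. Where it says the series, first, only, none or still open, it means among the compounds named here.

Of the compounds shown here, three have been read in an ADME assay on microsomes from liver (Mus musculus) for metabolic stability (on this read-out lower numbers stand for a shorter-lived compound and higher numbers for a longer-lived compound), so far. Compound 1 (`CC(C)C(Cc1ncc[nH]1)c1ccc(-c2ccc3cccc(F)c3c2)[nH]c1=O`) gives < 0.0667 h in this read-out, which is a limit of the assay and not a number, and it stands at the low end of the values shown. Compound 2 (`CCn1ncc2c(F)cc(-c3ccc(C(CC)(CC)c4nnc[nH]4)c(=O)[nH]3)cc21`) gives > 3 h in the same read-out, which is also a limit of the assay and not a number. Compound 3 (`CCC(CC)(c1nnc[nH]1)c1ccc(-c2ccc3cccc(F)c3c2)[nH]c1=O`) gives 0.447 h as a true number.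

Compound 4 (`CC(C)C(c1nnc[nH]1)c1ccc(-c2ccc3cccc(F)c3c2)[nH]c1=O`) has not yet been measured. Its structure departs from compound 1 in one place: 4H-1,2,4-triazol-3-yl in place of (1H-imidazol-2-yl)methyl on a saturated chain carbon bound to an aromatic carbon and a saturated chain carbon is the whole of the change. Among the measured compounds shown here, no measured pair of compounds isolates this swap, so any expectation is indirect. The nearest guide is compound 3, which gives 0.447 h while carrying the same 4H-1,2,4-triazol-3-yl on a saturated chain carbon. On that basis a rise in half-life beyond the usual scatter is expected, and the estimated step is an at least 3.7-fold higher number from compound 1 to compound 4 (0.57 log units; beyond the scatter) in this assay as a move towards longer life. Compound 4 is estimated at 0.25 h on this read-out, with an expected range from 0.1 h to 0.6 h for repeat measurements.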

Compound 4, half-life: 0.213 h
Compound 4: the middle estimate sits 1.2-fold (0.07 log units) above what was measured, and the stated range covers the measured number.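

In this assay, putting 4H-1,2,4-triazol-3-yl in place of (1H-imidazol-2-yl)methyl on a saturated chain carbon bound to an aromatic carbon and a saturated chain carbon gives an at least 3.1-fold higher number from compound 1 to compound 4 (0.50 log units; beyond the scatter), the first direct sign that the group at this place bears on half-life with the rest of the structure held fixed. Compound 1 gives < 0.0667 h, which is a limit of the assay and not a number. The true size of the step therefore remains unknown and may be larger than printed, because one end of it rests on a limit: the limit of < 0.0667 h in this assay, at which 1 of the 4 values shown sits.

The swap changes the ring and removes the methyl link in a single step, so the compounds shown do not separate what each of these changes contributes to the result. They also leave open how 1H-imidazol-2-yl joined directly to the chain carbon, (4H-1,2,4-triazol-3-yl)methyl, or a carboxylic acid at this place would read on this half-life scale.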